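The source may report more compounds than this note shows. Statements on the series, on what has been measured and on what is new or still open speak of the compounds shown alone.

Compound 1 `CCN(Cc1cccn1C)C(=O)COc1ccc(C)cc1` gives 21300 nM in an assay on HEK293 cells for agonist activity at transient receptor potential cation channel subfamily M member 8 (Homo sapiens), read by fluorescence and calcium flux, with a stated time of 15 min; a higher number here means that more compound is needed for the effect, a lower number that less compound is needed. Compound 2 `CCN(Cc1cccs1)C(=O)COc1ccc(C(C)C)cc1` gives 397 nM in this assay. Compound 3 `CCN(Cc1cccs1)C(=O)COc1ccc(C(=O)O)cc1` is reported as "not active" (no number reported) in this assay, with no number given, so it stands outside the measured range of the series on the shared core. Compound 4 `CCN(Cc1cccs1)C(=O)COc1ccc(F)cc1` is to be measured in this assay. The change from compound 3 to compound 4 is fluoro in place of carboxy on an aromatic carbon. For the measured compounds named here, no step between measured compounds covers this change; a return to measurable activity in this assay is expected, a large step toward less compound being needed, though compound 2 at 397 nM and compound 1 at 21300 nM suggest only modest potency for a small group. For compound 4 the expected value in this assay is 5000 nM, with a range from 1000 nM to 30000 nM.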

Compound 4, half-maximal effective concentration: 422 nM
The estimate for compound 4 lay 12-fold (1.07 log units) above the measured number, and the stated range ends above it.
By their numbers in this assay, from the lowest: compounds 2 and 4 (each within the scatter of the next); then compound 1.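

Replacing isopropyl with fluoro on this aromatic carbon, para to a large group, gives a 1.1-fold higher number from compound 2 to compound 4 (0.03 log units; within the scatter), so this assay does not separate these two groups on the shared core. For the compounds shown here, compound 3, with carboxy at the same carbon, remains the only one of the three compounds on this core without a number, so the "not active" report does not extend to every group other than isopropyl. Nothing available explains the match or the carboxy result.

Still open, going by these compounds, is whether an amine or a methoxy group on this carbon would give a number in the same range, and whether a methyl ester would do so where carboxy does not.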